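The source may report more compounds than this note shows. Statements on the series, on what has been measured and on what is new or still open speak of the compounds shown alone.

Three analogues sharing one core, differing only in the group carried on a saturated chain carbon bound to a sulfur, have been examined in an assay on isolated protein for inhibition of Norepinephrine transporter (Rattus norvegicus), read by radioligand binding; a lower number here means a stronger inhibitor, a higher number a weaker inhibitor. Compound 1 `COC(=O)C[S+]([O-])CC1CN(C)CCC1c1ccc(Cl)cc1` carries a methoxycarbonyl there and gives 53 nM. Compound 2 `CN1CCC(c2ccc(Cl)cc2)C(C[S+]([O-])CCO)C1`, with a hydroxymethyl in that place, gives 42 nM, and compound 3 `CC(=O)OCC[S+]([O-])CC1CN(C)CCC1c1ccc(Cl)cc1`, with an acetoxymethyl, gives 29 nM. Compound 3 sits at one end of a narrow spread: the step of a 1.8-fold lower number from compound 1 to compound 3 (0.26 log units; within the scatter) and the step of a 1.4-fold lower number from compound 2 to compound 3 (0.16 log units; within the scatter) are both within the scatter, as is a 1.3-fold lower number from compound 1 to compound 2 (0.10 log units; within the scatter), so the three compounds cannot be separated on these numbers.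

Compound 4 `CN1CCC(c2ccc(Cl)cc2)C(C[S+]([O-])CC(=O)NO)C1` continues the same series. The change from compound 3 is hydroxycarbamoyl in place of acetoxymethyl on a saturated chain carbon bound to a sulfur. Within the data shown here, every measured step so far bears on it, since each one swapped the group on this same chain carbon, and none of them moved the number beyond the scatter. On that basis no step beyond the scatter is expected for this assay either, in either direction. Compound 4 is therefore expected to give about 35 nM, with a likely range from 12 nM to 100 nM. The estimated step is a 1.2-fold higher number from compound 3 to compound 4 (0.08 log units; within the scatter). The measurement itself follows.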

Compound 4, inhibition constant: 12 nM
Compound 4: middle estimate off by 2.9-fold (0.46 log units), on the high side; low and high end bracket the measured number.
By their numbers in this assay, from the lowest: compound 4; then compounds 3, 2 and 1 (each within the scatter of the next).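

Until compound 4, no swap on this saturated chain carbon bound to a sulfur had moved the number in this assay beyond the scatter, so the position could have seemed indifferent to the group it carries. Hydroxycarbamoyl changes that picture, giving steps beyond the scatter against all three earlier groups, though each is modest: acetoxymethyl (a 2.4-fold lower number from compound 3 to compound 4 (0.38 log units; beyond the scatter)), hydroxymethyl (a 3.5-fold lower number from compound 2 to compound 4 (0.54 log units; beyond the scatter)) and methoxycarbonyl (a 4.4-fold lower number from compound 1 to compound 4 (0.65 log units; beyond the scatter)). The last comparison is the closest in structure, since the carbonyl stays in place and only hydroxyamino replaces methoxy, so a change on the carbonyl carbon alone is enough to separate compound 4 from compound 1. Nothing available explains why this group stands apart from the others.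

The compounds shown leave open whether the hydroxyl on the nitrogen matters, since a plain primary amide, a methoxyamino group or a carboxylic acid on the same carbonyl carbon does not appear among them. They also leave open whether the step would survive a longer chain between the sulfur and the hydroxycarbamoyl.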